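Working notes: sulfonyl substitution on the aromatic nitrogen

A few compounds are considered here, and "the series" means these few. Any claim that something is new, unique, unknown or untested is made for them only; others in the source may bear on it.

Measured compounds in a functional assay on HepG2 cells (Homo sapiens) for antiproliferative activity, with a stated time of 72 h; a higher number here means that more compound is needed for the effect, a lower number that less compound is needed:
compound 1, `COc1ccc(-c2cc(=O)c3c(OC)cc(OC)cc3[nH]2)cc1`, > 31100 nM
compound 2, `COc1ccc(-c2cc(=O)c3c(OC)cc(OC)cc3n2S(=O)(=O)c2c(F)c(F)c(F)c(F)c2F)cc1`, > 34400 nM

Compound 1 gives only (the limit of > 31100 nM in this assay, at which 1 of the 2 values shown sits), so its value is a limit of the assay and not a number. Compound 2 likewise gives only (the limit of > 34400 nM in this assay, at which 1 of the 2 values shown sits), again a limit rather than a number. Compound 1 therefore stands nowhere on a scale: the two values shown are both limits, and neither compound can be placed above or below the other. Going by the values given here, no step between measured compounds is available.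

Compound 3, `COc1ccc(-c2cc(=O)c3c(OC)cc(OC)cc3n2S(=O)(=O)Cc2ccccc2)cc1`, differs from compound 1 by benzylsulfonyl in place of hydrogen on an aromatic nitrogen. Compound 2 also carries a sulfonyl group on that aromatic nitrogen and stays at its limit, which is the only nearby point of reference. The expected step from compound 1 to compound 3 in this assay is none beyond the scatter: an at least 1.0-fold lower number from compound 1 to compound 3 (0.01 log units; that floor lies within the scatter). For compound 3 the estimated value is 30000 nM, with a range from 10000 nM to 60000 nM, and most likely the assay will again report only a limit.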

Compound 3, half-maximal effective concentration: > 34400 nM
Compound 3: only a limit was reported; the forecaster's own chance of this, stated with the estimate: 80%; middle value at least 1.1-fold (0.05 log units) from the limit.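

In this assay compound 3 gives only a limit and not a number: the limit of > 34400 nM in this assay, at which 2 of the 3 values shown sit.

Going by these compounds alone, compound 1, compound 2 and compound 3 all stand at limits, so no step between them can be read. The compounds shown leave open whether either sulfonyl group on the aromatic nitrogen changes the read-out at all, and where the true values of the three compounds lie.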